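Allyl in Place of 4-Chlorophenyl: An Untested Analogue

The compounds below may be only part of what the source reports. "The series", "measured", "known", "first", "only" and "open" are said of these compounds alone.

Of the compounds shown here, two have so far been measured in a functional assay on the whole organism with Rattus norvegicus as the target, at a dose of 100 mg/kg; on this read-out higher numbers stand for more inhibition at the one dose given (going by the name of the read-out) and lower numbers for less inhibition. Compound 1 `O=c1ccc(-c2ccccc2)nn1CCCCNC(=S)Nc1ccc(Cl)cc1` gives 43.2% in this assay, the higher of the two numbers. Compound 2 `C/N=C(/NC#N)NCCCn1nc(-c2ccccc2)c(C)cc1=O` gives 17.2% in this assay, a figure that lies beyond the usual scatter below the number for compound 1; the two compounds differ in more than one place, so no single step can be read from them. Compound 3 `C=CCNC(=S)NCCCCn1nc(-c2ccccc2)ccc1=O` has not yet been measured. It differs from compound 1 in one place: allyl in place of 4-chlorophenyl on an amide-type nitrogen. Among the compounds with values here, no measured pair shows the effect of such a change, and the comparison of compound 1 with compound 2 spans different cores and offers little guidance. Compound 3 is expected to lose some inhibition, with an estimated step of a number 13.2 percentage points lower from compound 1 to compound 3 (beyond the scatter). Compound 3 is accordingly estimated at 30%, within a range from 10% to 50%.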

Compound 3, a percentage reported as inhibition, in the whole organism at one dose (the size of the read-out at that dose, not a potency): 27.1%
Beside the measured number, compound 3's estimate is 2.9 percentage points above it; the measured number falls inside the stated range.
By their numbers in this assay, from the lowest: compounds 2 and 3 (each within the scatter of the next); then compound 1.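

In this assay, within the data shown here, allyl in place of 4-chlorophenyl on the amide-type nitrogen gives a number 16.1 percentage points lower from compound 1 to compound 3 (beyond the scatter), the first step that can be read at a single place and one that shows this position is sensitive to the group it carries. The aromatic ring is not needed for inhibition to be seen at this dose, as compound 3, whose allyl has no ring, still gives 27.1% in this assay. No available evidence bears on why the number falls.

The change removes the ring and the chlorine together, so the compounds shown do not tell their contributions apart. They leave open how an unsubstituted phenyl, a 4-methoxyphenyl or a saturated propyl would read on this nitrogen.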